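Compound 1 and its piperidin-1-yl counterpart

A few compounds are considered here, and "the series" means these few. Any claim that something is new, unique, unknown or untested is made for them only; others in the source may bear on it.

Compound 1 `CCC(=O)c1ccc2c(c1)sc(=O)n2CCN1CCCC1`: 13.9 mg/kg
Compound 2 `Oc1nc2ccc(Cc3ccc(F)cc3)cc2o1`: 125 mg/kg

In a functional assay on the whole organism with Mus musculus as the target, in the maximal electroshock model (on this read-out lower numbers stand for an effect already at smaller amounts and higher numbers for an effect only at larger amounts of compound), compound 1 has the lower of the two measured numbers at 13.9 mg/kg. Compound 2, at 125 mg/kg, lies above it by more than the usual scatter. Compound 3 `CCC(=O)c1ccc2c(c1)sc(=O)n2CCN1CCCCC1` keeps the core of compound 1 and differs in one place: piperidin-1-yl in place of pyrrolidin-1-yl on a saturated chain carbon, two bonds along the chain from an aromatic nitrogen. It carries piperidin-1-yl in place of pyrrolidin-1-yl on a saturated chain carbon, two bonds along the chain from an aromatic nitrogen. Within the data shown here, no measured pair shows this change, so the expectation rests on the structural change alone. A step within the scatter is expected in this assay, leaning slightly towards a higher number. The estimated move is a 1.3-fold higher number from compound 1 to compound 3 (0.11 log units; within the scatter). For compound 3 the expected value is 18 mg/kg, with an estimated range from 7 mg/kg to 45 mg/kg.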

Compound 3, dose for half-maximal effect: 8.7 mg/kg
Compound 3: middle estimate off by 2.1-fold (0.32 log units), on the high side; low and high end bracket the measured number.
By their numbers in this assay, from the lowest: compounds 3 and 1 (each within the scatter of the next); then compound 2.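

In this assay the exchange of pyrrolidin-1-yl for piperidin-1-yl is a 1.6-fold lower number from compound 1 to compound 3 (0.20 log units; within the scatter) and so stays within the scatter, which means the two rings cannot be told apart on this read-out. Among these compounds, at this place, on a saturated chain carbon, two bonds along the chain from an aromatic nitrogen, the five-membered ring can therefore give way to the six-membered ring without a change beyond the scatter, something the earlier compounds alone could not show. No independent measurement is available to explain this outcome.

From the compounds shown here alone, it remains open whether the same place also accepts a ring with a second hetero atom, such as morpholin-4-yl, or an open-chain amine such as dimethylamino. A longer chain between the aromatic nitrogen and the amine is equally unresolved.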